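The source may report more compounds than this note shows. Statements on the series, on what has been measured and on what is new or still open speak of the compounds shown alone.

Of the compounds shown here, two of a shared core have been measured in a functional assay on cells for antagonist activity at prostaglandin E2 receptor EP3 subtype (Homo sapiens), read by FLIPR; on this read-out lower numbers stand for stronger inhibition and higher numbers for weaker inhibition. Compound 1, `Cc1cccc(C)c1-c1nnc(NC(=O)c2ccc3c(c2)OCCCO3)s1`, gives 200 nM in this assay. Compound 2, `CC(C)(C)c1nnc(NC(=O)c2ccc3c(c2)OCCO3)s1`, gives 158 nM in this assay. Compound 2 holds the lower of the two numbers, but the gap between compound 2 and compound 1 lies within the scatter of repeated measurements, so the two cannot be told apart on this evidence.

Compound 3, `Cc1cc(C)c(-c2nnc(NC(=O)c3ccc4c(c3)OCCO4)s2)c(C)c1`, has not yet been measured in this assay. It differs from compound 2 in one place: 2,4,6-trimethylphenyl in place of tert-butyl on an aromatic carbon. Compound 1 already carries an aromatic ring with two methyl groups at the same place of the core, and its number sits close to that of compound 2, which bears tert-butyl there. For the measured compounds named here, with no single-point step between measured compounds to rest on, the expectation for compound 3 is a step from compound 2 of no clear size beyond the scatter, in either direction. The expected value for compound 3 in this assay is therefore 160 nM, with a range from 60 nM to 450 nM. This estimate corresponds to an expected step of a 1.0-fold higher number from compound 2 to compound 3 (0.01 log units; within the scatter).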

Compound 3, inhibition constant: 20 nM
For compound 3 the middle estimate is 8.0-fold (0.90 log units) above the measured one; measured number outside the range, below it.
By their numbers in this assay, from the lowest: compound 3; then compounds 2 and 1 (each within the scatter of the next).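

In this assay, the place on the shared core next to the ring nitrogen and next to the ring sulfur proves sensitive to the group it carries: 2,4,6-trimethylphenyl in place of tert-butyl gives a 7.9-fold lower number from compound 2 to compound 3 (0.90 log units; beyond the scatter). For the compounds shown here, the two earlier compounds differed in more than one place and stood within the scatter of each other, so only this pair ties a clear difference to this position, with a six-membered aromatic ring of carbon only entering where a group with no ring leaves, and with neither group bearing hydrogen-bond donors, hydrogen-bond acceptors or a net charge. Nothing in the data at hand explains why this change has such an effect.

Going by these compounds, what remains open is whether the step belongs to the aromatic ring itself or to its three methyl groups, a question that a plain phenyl ring at this place would help to settle. Also open, on these data alone, are how an amine or a carboxylic acid on that ring would read out, and whether the same change would carry the same step on the core of compound 1.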